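The compounds below may be only part of what the source reports. "The series", "measured", "known", "first", "only" and "open" are said of these compounds alone.

Measured so far:
compound 1 `CC(=O)O[C@@H]1OC(=O)[C@](C)(C(C)=O)[C@@H]1C`, 7000 nM
compound 2 `CC(=O)O[C@@H]1OC(=O)[C@@](C(C)=O)(C2SCCCS2)[C@@H]1C`, > 50000 nM
compound 3 `CC(=O)O[C@@H]1OC(=O)[C@@](C)(C(C)=O)[C@@H]1C`, 9000 nM

In a functional assay on DA-3 cells for cytotoxicity against DA-3 cell line (Mus musculus), read by MTT assay (on this read-out lower numbers stand for stronger inhibition and higher numbers for weaker inhibition), compound 3 gives 9000 nM, the higher of the two numbers that exist. Its nearest neighbour is compound 1 with 7000 nM, and the gap a 1.3-fold higher number from compound 1 to compound 3 (0.11 log units; within the scatter) stays within the scatter, as the two differ only in configuration (the fact that compounds 1 and 3 differ only in the configuration as drawn). In this assay compound 2 gives only a limit, > 50000 nM (the limit of > 50000 nM in this assay, at which 1 of the 3 values shown sits).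

Compound 4 `CC(=O)O[C@@H]1OC(=O)[C@@](OC(C)=O)(C(C)=O)[C@@H]1C` has not yet been measured; it carries acetoxy in place of methyl on a saturated ring carbon. For the measured compounds named here, one measured step touches the same ring carbon: an at least 7.1-fold higher number from compound 1 to compound 2 (0.85 log units; beyond the scatter), where a larger ring group replaced that methyl and the number went out to the limit. The acetoxy of compound 4 is a smaller group than that one, so a weakening beyond the scatter is expected, though a smaller one, and a 2.2-fold higher number from compound 3 to compound 4 (0.35 log units; beyond the scatter) is the step expected. Compound 4 is therefore estimated at 20000 nM in this assay, with a range from 7000 nM to 60000 nM.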

Compound 4, half-maximal inhibitory concentration: > 50000 nM
Compound 4 was reported as a limit; the forecaster's own chance of this, stated with the estimate: 30%; middle value at least 2.5-fold (0.39 log units) away from the limit.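

In this assay, acetoxy in place of methyl gives an at least 5.5-fold higher number from compound 3 to compound 4 (0.74 log units; beyond the scatter), so a group smaller than the ring group of compound 2 is already enough to reach the end of the measurable range. Replacing the methyl on this saturated ring carbon has now twice produced a much higher number, with two different groups, and compound 3 and compound 1 show that the drawn configuration alone does not do this. Compound 2 and compound 4 cannot be ranked against each other, as both stand at the same limit: the limit of > 50000 nM in this assay, at which 2 of the 4 values shown sit.

As far as these compounds go, it remains open whether an ethyl group or a hydroxyl group on this carbon would keep the number close to that of compound 3, at 9000 nM. The compounds shown also cannot separate the size of the entering group from its oxygen atoms.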